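Substituent on the fused ring and metabolic half-life

The source may hold more compounds than are shown below. What is called first, only, known or untested is meant among the compounds shown, and "the series" means these compounds.

Measured so far:
compound 1, `CC(C)CCn1nc(-c2cccs2)c(O)c(C2=NS(=O)(=O)c3ccccc3N2)c1=O`, 0.2 h;
compound 2, `CC(C)CCn1nc(-c2cccs2)c(O)c(C2=NS(=O)(=O)c3cc(O)ccc3N2)c1=O`, 0.0933 h;
compound 3, `CC(C)CCn1nc(-c2cccs2)c(O)c(C2=NS(=O)(=O)c3cc(OC(C)(C)C(N)=O)ccc3N2)c1=O`, 0.35 h.

These three share one core and differ only at one aromatic carbon of the fused ring. In an in vitro ADME assay on microsomes from liver (Homo sapiens) for metabolic stability, tested at 5 uM (a higher number here means that the compound lasts longer, a lower number that the compound disappears faster), compound 1 gives 0.2 h, the second highest of the three numbers; compound 3 sits within the scatter of it, while compound 2 lies beyond the scatter, lower.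

Compound 4, `CC(C)CCn1nc(-c2cccs2)c(O)c(C2=NS(=O)(=O)c3cc(OCC(=O)NO)ccc3N2)c1=O`, has not yet been measured. It differs from compound 1 by (hydroxycarbamoyl)methoxy in place of hydrogen on an aromatic carbon.

For the measured compounds named here, two measured steps bear on this. A bare hydroxy at that carbon gave a 2.1-fold lower number from compound 1 to compound 2 (0.33 log units; beyond the scatter). An ether carrying an amide, the 1-carbamoyl-1-methylethoxy group, gave a 1.8-fold higher number from compound 1 to compound 3 (0.24 log units; within the scatter). The new group is again an ether with an amide, now a hydroxycarbamoyl, so the half-life of compound 4 is expected to stay close to that of compound 1, with no step beyond the scatter: a 1.2-fold lower number from compound 1 to compound 4 (0.07 log units; within the scatter). For compound 4 the estimate in this assay is 0.17 h, with a range from 0.07 h to 0.4 h.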

Compound 4, half-life: > 1 h
Compound 4: only a limit was reported (the forecaster's own chance of this, stated with the estimate: 5%); middle value at least 5.8-fold (0.76 log units) from the limit.
By their numbers in this assay, from the lowest: compound 2; then compounds 1 and 3 (each within the scatter of the next). At a limit, above all of these: compound 4.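

For compound 4 the result is a limit and not a number: the limit of > 1 h in this assay, at which 1 of the 4 values shown sits. Even so, it shows what the earlier compounds did not, that a group at this aromatic carbon can clearly lengthen the half-life in this assay: (hydroxycarbamoyl)methoxy in place of hydrogen gives an at least 5.0-fold higher number from compound 1 to compound 4 (0.69 log units; beyond the scatter), whereas the rise with 1-carbamoyl-1-methylethoxy stayed within the scatter, and capping the bare hydroxy of compound 2 with the new chain gives an at least 10-fold higher number from compound 2 to compound 4 (1.03 log units; beyond the scatter). Two amide-bearing ethers are also not interchangeable here, since exchanging one for the other gives an at least 2.8-fold higher number from compound 3 to compound 4 (0.45 log units; beyond the scatter).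

From the compounds shown here alone, how far the half-life of compound 4 lies past its limit remains unknown. Which part of the new chain matters also stays open, and a carbamoylmethoxy group, a carboxylic acid or a longer chain at the same carbon would help to separate these parts.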